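Changing the group on the boron-bound carbon: towards compound 3

The source may hold more compounds than are shown below. What is called first, only, known or untested is meant among the compounds shown, and "the series" means these compounds.

Measured so far in a functional assay on HCT-116 cells (Homo sapiens) for antiproliferative activity, read by MTT assay, with a stated time of 72 h; a lower number here means a stronger inhibitor, a higher number a weaker inhibitor
Compound 1 `CC1(C)OB([C@H](CCc2ccccc2)NC(=O)N2C/C(=C\c3ccc(F)cc3)C(=O)/C(=C/c3ccc(F)cc3)C2)OC1(C)C` gives 1040 nM
Compound 2 `CC(C)(C)[C@H](NC(=O)N1C/C(=C\c2ccc(F)cc2)C(=O)/C(=C/c2ccc(F)cc2)C1)B1OC(C)(C)C(C)(C)O1` gives 828 nM

Among the measured compounds shown here, compound 2 stands level with compound 1, the only other compound measured: a 1.3-fold lower number from compound 1 to compound 2 (0.10 log units; within the scatter). Compound 3 `CC1(C)OB([C@@H](NC(=O)N2C/C(=C\c3ccc(F)cc3)C(=O)/C(=C/c3ccc(F)cc3)C2)C2CCCCC2)OC1(C)C` is still to be measured. It has cyclohexyl in place of tert-butyl on a saturated chain carbon bound to an amide-type nitrogen and a boron atom. For the measured compounds named here, only one measured step bears on this place, the exchange of phenethyl for tert-butyl, with compound 1 at 1040 nM and compound 2 at 828 nM. Going by the values given here, that single step stayed within the scatter, and no measured compound carries cyclohexyl here. No step beyond the scatter is therefore expected in this assay, in either direction. The expected step is a 1.1-fold higher number from compound 2 to compound 3 (0.04 log units; within the scatter). The estimate for compound 3 is 900 nM, with an expected range of 450 nM to 1800 nM.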

Compound 3, half-maximal inhibitory concentration: 903 nM
Beside the measured number, compound 3's estimate is 1.0-fold (0.00 log units) below it; low and high end bracket the measured number.
By their numbers in this assay, from the lowest: compounds 2, 3 and 1 (each within the scatter of the next).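

In this assay, cyclohexyl puts a six-membered ring of carbon on the saturated chain carbon bound to an amide-type nitrogen and a boron atom, and the result is a 1.1-fold higher number from compound 2 to compound 3 (0.04 log units; within the scatter) and, against the phenethyl compound, a 1.2-fold lower number from compound 1 to compound 3 (0.06 log units; within the scatter) with both steps inside the scatter. With this third group, the ring of cyclohexyl joins phenethyl and tert-butyl as a change at this place that gives no step beyond the scatter among the compounds shown, and no listed compound goes against that. No supporting data accompany these numbers to account for this.

As far as these compounds go, whether an amine or a carboxylic acid on this carbon would give a step beyond the scatter stays open. So does whether a longer chain at this place would stay level with these three compounds.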